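Half-life in human liver microsomes: from compound 3 to compound 4

The source may hold more compounds than are shown below. What is called first, only, known or untested is meant among the compounds shown, and "the series" means these compounds.

Measured compounds and values:
compound 1 `CCOC(=O)c1cn(Cc2nnc(-c3cc(S(N)(=O)=O)c(SCc4ccccc4)cc3Cl)o2)nn1` — 0.085 h
compound 2 `NCc1nnc(-c2cc(S(N)(=O)=O)c(SCc3ccccc3)cc2Cl)o1` — 0.263 h
compound 3 `NS(=O)(=O)c1cc(-c2nnc(CNS(=O)(=O)c3ccc(Cl)cc3)o2)c(Cl)cc1SCc1ccccc1` — 0.197 h

The three compounds share one core and differ only in the group on the saturated chain carbon attached to the five-membered ring. In an ADME assay on microsomes from liver (Homo sapiens) for metabolic stability, read by LC-MS, using NADPH, tested at 5 uM (a higher number here means that the compound lasts longer, a lower number that the compound disappears faster), compound 3 gives 0.197 h and stands second of the three numbers: its step to compound 2 lies within the scatter, while compound 1 lies clearly lower.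

Compound 4 `NS(=O)(=O)c1cc(-c2nnc(/C=C/c3ccc(Cl)cc3)o2)c(Cl)cc1SCc1ccccc1` is not yet measured. It differs from compound 3 in one place: 2-(4-chlorophenyl)ethenyl in place of (((4-chlorophenyl)sulfonyl)amino)methyl on an aromatic carbon.

Among the compounds with values here, no measured pair shows this change. The measured steps tell only that moving away from the ester-bearing triazole raises the number, as seen in a 3.1-fold higher number from compound 1 to compound 2 (0.49 log units; beyond the scatter) and a 2.3-fold higher number from compound 1 to compound 3 (0.37 log units; beyond the scatter), and that adding the sulfonyl group to the amine produced a 1.3-fold lower number from compound 2 to compound 3 (0.13 log units; within the scatter), a step within the scatter. None of these involves a double-bond-linked aryl group, so the direction for compound 4 cannot be read from them.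

Compound 4 is therefore expected to sit near compound 3, with an estimated step of a 1.2-fold lower number from compound 3 to compound 4 (0.06 log units; within the scatter), which is not beyond the scatter. The estimate for compound 4 is 0.17 h, expected to lie between 0.06 h and 0.45 h.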

Compound 4, half-life: 0.207 h
Compound 4: middle estimate off by 1.2-fold (0.09 log units), on the low side, and the stated range covers the measured number.
By their numbers in this assay, from the lowest: compound 1; then compounds 3, 4 and 2 (each within the scatter of the next).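

In this assay, swapping the whole (((4-chlorophenyl)sulfonyl)amino)methyl group for 2-(4-chlorophenyl)ethenyl gives a 1.1-fold higher number from compound 3 to compound 4 (0.02 log units; within the scatter), so at this position the read-out does not register the loss of the sulfonyl group, the amine nitrogen and their hydrogen-bond donor and acceptors. The same holds against the much smaller aminomethyl group, with a 1.3-fold lower number from compound 2 to compound 4 (0.10 log units; within the scatter), so three quite different groups on this aromatic carbon now cannot be told apart in half-life. Only the (4-(ethoxycarbonyl)-1H-1,2,3-triazol-1-yl)methyl group stands apart, as a 2.4-fold higher number from compound 1 to compound 4 (0.39 log units; beyond the scatter) shows, and compounds 2, 3 and 4 all lie beyond the scatter from compound 1, which makes that group the one clear outlier among the four.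

Nothing available explains why the half-life stays so similar across such different groups. The compounds shown leave open whether the double bond matters, which the saturated 2-(4-chlorophenyl)ethyl group would address, and whether the short half-life of compound 1 is tied to its ethyl ester, which a carboxylic acid in its place on the triazole would address.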